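The source may report more compounds than this note shows. Statements on the series, on what has been measured and on what is new or still open speak of the compounds shown alone.

Measured compounds:
compound 1 `CC(C)CCC1(O)C(=O)Nc2ccc(Nc3ccc(F)cc3)cc21` gives 16800 nM in a functional assay on NCI-H460 cells (Homo sapiens) for antiproliferative activity, read by MTT assay, with a stated time of 48 h; a lower number here means a stronger inhibitor, a higher number a weaker inhibitor;
compound 2 `CCCCCCC1(O)C(=O)Nc2ccc(Nc3ccc(F)cc3)cc21` gives 50700 nM in this assay;
compound 3 `CC(C)CCC1(O)C(=O)Nc2ccc(Nc3ccc(C(F)(F)F)cc3)cc21` gives 17200 nM in this assay.

Compound 2 differs from compound 1 by butyl in place of isopropyl on a saturated chain carbon, two bonds along the chain from a saturated ring carbon. That single change produced a 3.0-fold higher number from compound 1 to compound 2 (0.48 log units; beyond the scatter), so the straight chain made the compound a weaker inhibitor in this small set. Compound 3 differs from compound 1 by trifluoromethyl in place of fluoro on an aromatic carbon, and this gave a 1.0-fold higher number from compound 1 to compound 3 (0.01 log units; within the scatter), a step that does not rise above ordinary measurement scatter.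

Compound 4 `CCCCCCC1(O)C(=O)Nc2ccc(Nc3ccc(C(F)(F)F)cc3)cc21` has not yet been measured. It differs from compound 3 by butyl in place of isopropyl on a saturated chain carbon, two bonds along the chain from a saturated ring carbon, the same change that separates compound 1 from compound 2, in the same place. Going by the values given here, compound 4 is expected to sit about a 2.9-fold higher number from compound 3 to compound 4 (0.46 log units; beyond the scatter) away from compound 3 in this assay, because the only earlier example of this change gave a 3.0-fold higher number from compound 1 to compound 2 (0.48 log units; beyond the scatter). Compound 4 is therefore estimated at 50000 nM in this assay, with a plausible range from 25000 nM to 100000 nM, resting on a single earlier pair.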

Compound 4, half-maximal inhibitory concentration: 18800 nM
Compound 4: middle estimate off by 2.7-fold (0.42 log units), on the high side, outside the stated range (below it).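

With trifluoromethyl in place of fluoro, the chain change gave a 1.1-fold higher number from compound 3 to compound 4 (0.04 log units; within the scatter) in this assay, so its size did not carry over from the core of compound 1: the same change on two cores in this assay, a 3.0-fold higher number (0.48 log units; beyond the scatter) from compound 1 to compound 2 and a 1.1-fold higher number (0.04 log units; within the scatter) from compound 3 to compound 4, 2.8-fold (0.44 log units) apart, beyond the scatter of two such steps

Read the other way, trifluoromethyl in place of fluoro gave a 2.7-fold lower number from compound 2 to compound 4 (0.43 log units; beyond the scatter) with the butyl change in place, a step unlike the earlier one, so the two changes do not simply add up: the same change on two cores in this assay, a 1.0-fold higher number (0.01 log units; within the scatter) from compound 1 to compound 3 and a 2.7-fold lower number (0.43 log units; beyond the scatter) from compound 2 to compound 4, 2.8-fold (0.44 log units) apart, beyond the scatter of two such steps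

Going by these compounds alone, both comparisons use the same four compounds and are one finding, not two; they show that the effect of one change depends on the other here, but they do not show why, and the mismatch hangs on the single value of compound 2.

Going by these compounds, it remains open whether a longer chain, or a chain ending in an amine, would follow compound 2 or compound 4. Also open, on these data alone, is how a chloro group or a methoxy group on the aromatic ring would behave with either chain.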